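Replacing 2-bromophenyl on the sulfonyl sulfur of compound 3

A few compounds are considered here, and "the series" means these few. Any claim that something is new, unique, unknown or untested is made for them only; others in the source may bear on it.

Of the compounds shown here, three sharing one core have been tested in a functional assay on HEK293 cells (Homo sapiens) for cytotoxicity; on this read-out higher numbers stand for lower toxicity in this test and lower numbers for higher toxicity in this test. Compound 1 `COc1ccc([C@H]2CC(=O)N(c3cccc(NCCCc4ccccc4)c3)C2)cc1OC1CCCC1` carries 3-phenylpropyl on a nitrogen, and its result is only a limit, > 10000 nM. Compound 2 `COc1ccc([C@H]2CC(=O)N(c3cccc(NS(=O)(=O)c4ccccc4F)c3)C2)cc1OC1CCCC1` carries (2-fluorophenyl)sulfonyl there, and its result is also a limit, > 10000 nM. Compound 3 `COc1ccc([C@H]2CC(=O)N(c3cccc(NS(=O)(=O)c4ccccc4Br)c3)C2)cc1OC1CCCC1` carries (2-bromophenyl)sulfonyl, and it too gives only a limit, > 10000 nM. Compound 3 thus shares (the limit of > 10000 nM in this assay, at which 3 of the 3 values shown sit), and it has no number of its own.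

Compound 4 `COc1ccc([C@H]2CC(=O)N(c3cccc(NS(=O)(=O)c4c(Br)nn(C)c4Cl)c3)C2)cc1OC1CCCC1` differs from compound 3 in one place: 3-bromo-5-chloro-1-methyl-1H-pyrazol-4-yl in place of 2-bromophenyl on a sulfonyl sulfur. The new group, 3-bromo-5-chloro-1-methyl-1H-pyrazol-4-yl, stands in place of 2-bromophenyl on a sulfonyl sulfur. The closest measured change, bromo in place of fluoro on an aromatic carbon, is a step that the two limits leave unreadable from compound 2 to compound 3. The two changes from 3-phenylpropyl to a sulfonyl group are a step that the two limits leave unreadable from compound 1 to compound 2 and a step that the two limits leave unreadable from compound 1 to compound 3. None of these gives a size to carry over, and none involves a pyrazole group.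

With nothing to suggest a move in either direction, no step beyond the scatter is expected in this assay. The expected change is a step that the limit leaves unreadable from compound 3 to compound 4. A further reading at the limit is the likeliest outcome. For compound 4 the estimate is 12000 nM, with an expected range from 5000 nM to 30000 nM.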

Compound 4, half-maximal cytotoxic concentration: > 10000 nM
Compound 4 ended at the assay's limit; the forecaster's own chance of this, stated with the estimate: 80%; the middle value lies beyond the limit too.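

Compound 4, like compounds 1, 2 and 3, gives only a limit in this assay, so no step among these four compounds can be read: the limit of > 10000 nM in this assay, at which 4 of the 4 values shown sit.

The compounds shown leave open whether any group on the shared core would give a measurable number in this assay, and how far apart these four compounds truly lie.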